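Adding methoxy to the benzyl group of compound 3

This account rests on a few compounds, and the source may have more. Where it says the series, first, only, none or still open, it means among the compounds named here.

In a functional assay on a cell-free system (Platelet, plasma, Homo sapiens) for inhibition, with stated times of 1 min and 3 min (on this read-out higher numbers stand for weaker inhibition and lower numbers for stronger inhibition), compound 3 (`CCCSc1nc(NCc2ccccc2)c2ncn([C@@H]3O[C@H](CO)[C@@H](O)[C@H]3O)c2n1`) gives 216000 nM and compound 2 (`CCCSc1nc(NC2CCCCC2)c2ncn([C@@H]3O[C@H](CO)[C@@H](O)[C@H]3O)c2n1`) gives 151000 nM. Among the compounds with values here, these are the only numbers. Compound 1 (`CCSc1nc(NCc2ccc(OC)cc2)c2ncn([C@@H]3O[C@H](CO)[C@@H](O)[C@H]3O)c2n1`) already carries 4-methoxybenzyl, but for compound 1 the result is "not determined" (no result reported), so it offers no comparison. Compound 4 (`CCCSc1nc(NCc2ccc(OC)cc2)c2ncn([C@@H]3O[C@H](CO)[C@@H](O)[C@H]3O)c2n1`) follows from compound 3 by methoxy in place of hydrogen on an aromatic carbon, para to a large group. Within the data shown here, the only measured step, a 1.4-fold higher number from compound 2 to compound 3 (0.16 log units; within the scatter), concerns a different change and gives no direction for methoxy. No shift beyond the scatter is therefore expected in this assay. The expected step is a 1.1-fold lower number from compound 3 to compound 4 (0.03 log units; within the scatter). For compound 4 the estimated value is 200000 nM, with an expected range of 90000 nM to 420000 nM.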

Compound 4, half-maximal inhibitory concentration: 181000 nM
Compound 4: middle estimate off by 1.1-fold (0.04 log units), on the high side, within the range that was stated.
By their numbers in this assay, from the lowest: compounds 2, 4 and 3 (each within the scatter of the next).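

In this assay, methoxy in place of hydrogen on the aromatic carbon para to a large group gives a 1.2-fold lower number from compound 3 to compound 4 (0.08 log units; within the scatter), so this change on the benzyl group shows no shift beyond the scatter. Setting 4-methoxybenzyl in place of cyclohexyl gives a 1.2-fold higher number from compound 2 to compound 4 (0.08 log units; within the scatter), which also lies within the scatter. Nothing available bears on why these numbers stay so close.

Going by these compounds, whether an amine or a carboxylic acid at this ring carbon would move the number beyond the scatter remains open. So does the effect of a butyl chain in place of the propyl chain on sulfur.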